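Methoxy added to the phenoxy ring of a nitrocatechol ketone

A few compounds are considered here, and "the series" means these few. Any claim that something is new, unique, unknown or untested is made for them only; others in the source may bear on it.

Measured compounds:
compound 1 `O=C(COc1ccccc1)c1cc(O)c(O)c([N+](=O)[O-])c1`, -4%
compound 2 `CCN(CC)CCC(=O)c1cc(O)c(O)c([N+](=O)[O-])c1`, -26%

In an assay on the whole organism (brain) for inhibition of Catechol O-methyltransferase (Mus musculus), with a stated time of 6 h, at a dose of 30 mg/kg by the oral route (a higher number here means more inhibition at the dose given (going by the name of the read-out), a lower number less inhibition), compound 1 gives -4%, the higher of the two numbers; compound 2 lies a number 22 percentage points lower from compound 1 to compound 2 (beyond the scatter). Compound 3 `COc1ccc(OCC(=O)c2cc(O)c(O)c([N+](=O)[O-])c2)cc1` differs from compound 1 by methoxy in place of hydrogen on an aromatic carbon. Within the data shown here, the one measured step swaps the whole phenoxy group and so does not bear directly on adding a methoxy to it; no step here tests this change. A step within the scatter is therefore expected, a number 1 percentage points lower from compound 1 to compound 3 (within the scatter). Compound 3 is estimated at -5%, between -30% and 20%.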

Compound 3, a percentage reported as inhibition, in the whole organism at one dose (the size of the read-out at that dose, not a potency): 7%
Estimate against measurement, compound 3: 12 percentage points below; measured number inside the range.
By their numbers in this assay, from the lowest: compound 2; then compound 1; then compound 3.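

In this assay, methoxy in place of hydrogen on an aromatic carbon, para to a large group, gives a number 11 percentage points higher from compound 1 to compound 3 (beyond the scatter) and thus a step beyond the scatter. The earlier pair exchanged the whole phenoxy group, whereas this step shows that a change on the phenoxy ring alone, with the shared core untouched, can raise the number. Nothing measured here explains this step.

On these data alone, it remains open whether a chlorine atom, an amine or a longer alkoxy chain on the same carbon would raise the number as well. As far as these compounds go, whether methoxy would do so elsewhere on the ring also remains open.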